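The source may hold more compounds than are shown below. What is called first, only, known or untested is meant among the compounds shown, and "the series" means these compounds.

Measured so far:
compound 1 `N#Cc1ccc(-n2c(=O)n(Cc3ccccc3)c3cccnc32)cc1C(F)(F)F`; in a physicochemical assay for solubility (a higher number here means a more soluble compound, a lower number a less soluble compound), compound 1 gives < 500 nM, which is a limit of the assay and not a number (the limit of < 500 nM in this assay, at which 1 of the 3 values shown sits).
compound 2 `Cc1ccc(-n2c(=O)n(-c3ccc(C#N)c(C(F)(F)F)c3)c3ccccc32)cc1`; in this assay compound 2 gives 790 nM.
compound 3 `CNC(=O)c1ccc(-c2ccc3c(c2)C(C)(C)C(=O)N3c2ccc(C#N)c(OC)c2)cc1F`; in this assay compound 3 gives 9700 nM.

Among the two numbers that are not limits, compound 2 stands lowest; compound 3 lies well beyond the scatter above it. Compound 4 `CCn1c(=O)n(-c2ccc(C#N)c(C(F)(F)F)c2)c2ccccc21` has not yet been measured. It differs from compound 2 in one place: ethyl in place of 4-methylphenyl on an aromatic nitrogen.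

For the measured compounds named here, no measured pair shows a change of this kind, so the direction of the step rests on expectation alone. A modest rise in this assay is expected for compound 4, the step of a 2.5-fold higher number from compound 2 to compound 4 (0.40 log units; beyond the scatter) probably exceeding the scatter but falling short of the gap to compound 3. Compound 4 is therefore estimated at 2000 nM, in the range 600 nM to 7000 nM.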

Compound 4, solubility: 3470 nM
Beside the measured number, compound 4's estimate is 1.7-fold (0.24 log units) below it, within the range that was stated.
By their numbers in this assay, from the lowest: compound 2; then compound 4; then compound 3. At a limit, below all of these: compound 1.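

For the compounds shown here, this is the first pair in this assay that differs in one place only, and it gives the aromatic nitrogen a measured direction: ethyl in place of 4-methylphenyl brings a 4.4-fold higher number from compound 2 to compound 4 (0.64 log units; beyond the scatter). The group on this nitrogen therefore matters to this read-out, at least for this one change. Nothing measured here accounts for the step.

A single pair cannot separate the loss of the ring from the drop in heavy atoms. Going by these compounds, how a propyl chain, an amine or a carboxylic acid at this position would read in this assay also remains open.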